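The source may report more compounds than this note shows. Statements on the series, on what has been measured and on what is new or still open speak of the compounds shown alone.

Measured compounds:
compound 1, `O=C(NCCNS(=O)(=O)c1ccc(-c2ccccc2Oc2ccc(O)c(O)c2)s1)Nc1cc(Cl)cc(Cl)c1`, > 20000 nM
compound 2, `O=C(Nc1cccc([N+](=O)[O-])c1)N1CCN(S(=O)(=O)c2sccc2-c2ccccc2Oc2ccc(O)c(O)c2)CC1`, > 20000 nM
compound 3, `O=S(=O)(NCCNC(=S)Nc1cccc(Cl)c1)c1ccc(-c2ccccc2OCc2ccccc2)s1`, 8400 nM

All three were tested in a functional assay on HeLa cells (Homo sapiens) for inhibition, read by CCK-8 assay, with a stated time of 48 h; a lower number here means a stronger inhibitor, a higher number a weaker inhibitor. Within the data shown here, compound 3 is the only one of the three that gives a number, 8400 nM, so there is no measured step against which to set it. For compound 1 the result in this assay is only a limit, > 20000 nM, not a number. For compound 2 likewise the result in this assay is a limit, > 20000 nM. What frames the series is the limit of > 20000 nM in this assay, at which 2 of the 3 values shown sit. Compound 4, `O=[N+]([O-])c1ccc(NC(=S)NCCNS(=O)(=O)c2ccc(-c3ccccc3OCc3ccccc3)s2)cc1`, has not yet been measured. It differs from compound 3 in one place: 4-nitrophenyl in place of 3-chlorophenyl on an amide-type nitrogen. Among the measured compounds shown here, since no measured pair among the three compounds shows what such a change does, the step expected in this assay is a 1.2-fold higher number from compound 3 to compound 4 (0.08 log units; within the scatter), which is meant as no shift beyond the scatter in either direction. For compound 4 in this assay the estimate is therefore 10000 nM, with a range from 3000 nM to 30000 nM.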

Compound 4, half-maximal inhibitory concentration: 7100 nM
For compound 4 the middle estimate is 1.4-fold (0.15 log units) above the measured one; the range from low to high includes it.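

Placing 4-nitrophenyl in place of 3-chlorophenyl on an amide-type nitrogen gives the first measured step of this series in this assay: a 1.2-fold lower number from compound 3 to compound 4 (0.07 log units; within the scatter). The two groups differ in their heavy atoms and hydrogen-bond acceptors, yet this read-out does not tell them apart, so this position tolerates at least this one exchange. Compound 3 and compound 4 both give a number rather than a limit, which matters in a series framed by that limit: the limit of > 20000 nM in this assay, at which 2 of the 4 values shown sit.

A single pair cannot show whether other groups at this position would behave the same way, such as a plain phenyl, an aminophenyl or a carboxyphenyl. It also leaves open whether any change here can move the number beyond the scatter.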